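This account rests on a few compounds, and the source may have more. Where it says the series, first, only, none or still open, it means among the compounds named here.

Measured compounds in an ADME assay on MT4 cells (Homo sapiens) for cytotoxicity, read by MTT assay; on this read-out lower numbers stand for higher toxicity in this test and higher numbers for lower toxicity in this test:
compound 1 `O=C(CSc1nnnn1-c1cccc2ccccc12)N/N=C/c1ccc(Cl)cc1`: > 295000 nM, a limit of the assay
compound 2 `O=C(CSc1nnnn1-c1cccc2ccccc12)N/N=C/c1ccc([N+](=O)[O-])cc1`: >= 260000 nM, a limit of the assay
compound 3 `Cc1cccc(/C=N/NC(=O)CSc2nnnn2-c2cccc3ccccc23)c1`: 269000 nM

Going by the values given here, compound 3 is the only member of this set for which this assay gives a number; the two other values are limits. Compound 1 sits at the limit of > 295000 nM in this assay, at which 1 of the 3 values shown sits. Compound 2 sits at the limit of >= 260000 nM in this assay, at which 1 of the 3 values shown sits. All three compounds share the same core, and only the aryl group on the carbon with a double bond to nitrogen changes.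

Compound 4 `O=C(CSc1nnnn1-c1cccc2ccccc12)N/N=C/c1cccc(O)c1` differs from compound 3 by hydroxy in place of methyl on an aromatic carbon. Among the compounds with values here, no measured step exchanges methyl for hydroxy on this ring. The nearest comparison, an at least 1.0-fold lower number from compound 1 to compound 3 (0.04 log units; that floor lies within the scatter), shows that exchanging one substituted phenyl for another left the read-out essentially where it was. The steps a step that the two limits leave unreadable from compound 1 to compound 2 and a step that the limit leaves unreadable from compound 2 to compound 3 give no readable size, as their values are limits. All three measured compounds lie at or near the upper end of what this assay reports.

Compound 4 is therefore expected to show a 1.1-fold lower number from compound 3 to compound 4 (0.03 log units; within the scatter), no step beyond the scatter. Compound 4 is estimated at 250000 nM, within 120000 nM to 300000 nM, and this assay may again report only a limit for compound 4.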

Compound 4, half-maximal cytotoxic concentration: 169000 nM
Beside the measured number, compound 4's estimate is 1.5-fold (0.17 log units) above it, within the range that was stated.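

In this assay the step of a 1.6-fold lower number from compound 3 to compound 4 (0.20 log units; within the scatter) stays within the scatter, so on this aromatic carbon, meta to a large group, hydroxy in place of methyl brings in a hydrogen-bond donor and a hydrogen-bond acceptor with no readable change in the read-out. Compound 4 also gives a number rather than a limit of the assay, so this position now has two measured values to compare, which the earlier set could not offer with compound 3 alone. The wider exchanges add no more than that, since the floors in the step of an at least 1.5-fold lower number from compound 2 to compound 4 (0.18 log units; that floor lies within the scatter) and the step of an at least 1.7-fold lower number from compound 1 to compound 4 (0.24 log units; that floor lies within the scatter) both rest on limits of the assay and both lie within the scatter.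

From the compounds shown here alone, whether an amine, a carboxylic acid or a longer chain such as ethoxy on this carbon of the 3-substituted phenyl would carry the read-out beyond the scatter stays open, as does whether hydroxy would behave alike elsewhere on the ring. Nothing measured in this set speaks to what lies behind the size of the methyl to hydroxy step.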